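This account rests on a few compounds, and the source may have more. Where it says the series, first, only, none or still open, it means among the compounds named here.

In a functional assay with Oryctolagus cuniculus as the target (on this read-out lower numbers stand for stronger inhibition and higher numbers for weaker inhibition), compound 3 (`CCOC(=O)/C=C/c1nc(-c2ccc(OC)cc2)c(-c2ccc(OC)cc2)s1`) gives 20 nM and compound 1 (`CNC(=O)NCc1nc(-c2ccc(OC)cc2)c(-c2ccc(OC)cc2)s1`) gives 22 nM on the same read-out. These two values stand level, with a 1.1-fold lower number from compound 1 to compound 3 (0.04 log units; within the scatter) between them. Compound 2 (`CCOC(=O)/C(C#N)=C/c1nc(-c2ccc(OC)cc2)c(-c2ccc(OC)cc2)s1`) reads < 10 nM as a limit of the assay. Exchanging the group on an aromatic carbon gave an at least 2.2-fold lower number from compound 1 to compound 2 (0.34 log units; beyond the scatter) in one case and an at least 2.0-fold higher number from compound 2 to compound 3 (0.30 log units; that floor lies within the scatter) in another. Compound 4 (`COc1ccc(-c2nc(C3=CCN(C)CC3)sc2-c2ccc(OC)cc2)cc1`) brings a further exchange at that carbon, where a group of 7 heavy atoms (6 carbon, 1 nitrogen; one six-membered non-aromatic ring with 1 hetero atom) in place of a group of 7 heavy atoms (5 carbon, 2 oxygen; no ring), on an aromatic carbon replaces 2-(ethoxycarbonyl)ethenyl. The closest guide is a 1.1-fold lower number from compound 1 to compound 3 (0.04 log units; within the scatter) for an equally large exchange, while compound 2 is the one that goes against a flat picture. The expected step is a 1.3-fold higher number from compound 3 to compound 4 (0.10 log units; within the scatter) and no shift beyond the scatter is foreseen. For compound 4 the estimate is 25 nM with an expected range from 7 nM to 90 nM here.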

Compound 4, half-maximal inhibitory concentration: < 10 nM
Compound 4: no number, only a limit; the forecaster's own chance of this, stated with the estimate: 15%; middle value at least 2.5-fold (0.39 log units) from the limit.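

In this assay compound 4 reads < 10 nM, a limit of the assay and not a number. The earlier groups at this aromatic carbon have no ring, so this shows that a six-membered non-aromatic ring with 1 hetero atom is accepted here, with an at least 2.2-fold lower number from compound 1 to compound 4 (0.34 log units; beyond the scatter). The comparison with the ethenyl ester gives an at least 2.0-fold lower number from compound 3 to compound 4 (0.30 log units; that floor lies within the scatter), and that floor does not establish a real gain.

As far as these compounds go, the step between compound 2 and compound 4 cannot be read, because both values rest on the same limit: the limit of < 10 nM in this assay, at which 2 of the 4 values shown sit. How a carboxylic acid or an open-chain amine would read at this carbon remains open.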